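The source may report more compounds than this note shows. Statements on the series, on what has been measured and on what is new or still open speak of the compounds shown alone.

Compound 1 `CCCCCCOc1c(-c2cc(OC)c(OC)c(OC)c2)oc2ccccc2c1=O`: 19600 nM
Compound 2 `CCCCN(CCCC)CCCCCOc1c(-c2cc(OC)c(OC)c(OC)c2)oc2ccccc2c1=O`: 7800 nM
Compound 3 `CCCCCN(CCCCC)CCCOc1c(-c2cc(OC)c(OC)c(OC)c2)oc2ccccc2c1=O`: not yet measured

In a functional assay on LNCaP cells (Homo sapiens) for antiproliferative activity, read by WST assay, with a stated time of 3 days (a lower number here means a stronger inhibitor, a higher number a weaker inhibitor), compound 2 holds the lower of the two numbers, at 7800 nM. The next change is dipentylamino in place of 2-(dibutylamino)ethyl on a saturated chain carbon, three bonds along the chain from an oxygen on an aromatic ring. The two compounds have the same atoms, joined differently, with dipentylamino in place of 2-(dibutylamino)ethyl on a saturated chain carbon, three bonds along the chain from an oxygen on an aromatic ring.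

Among the measured compounds shown here, only one measured step bears on this, and only indirectly: a 2.5-fold lower number from compound 1 to compound 2 (0.40 log units; beyond the scatter), a modest step that brought in dibutylamino in place of methyl. For the measured compounds named here, no measured pair shows a swap of this kind, and compound 3 retains an amino group, so no step beyond the scatter is expected in this assay. The expected step is a 1.0-fold higher number from compound 2 to compound 3 (0.01 log units; within the scatter), with its direction open. Compound 3 is estimated at 8000 nM, with an expected range of 3500 nM to 18000 nM.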

Compound 3, half-maximal inhibitory concentration: 5100 nM
Estimate against measurement, compound 3: 1.6-fold (0.20 log units) above; low and high end bracket the measured number.
By their numbers in this assay, from the lowest: compounds 3 and 2 (each within the scatter of the next); then compound 1.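

In this assay, moving the nitrogen along the same atoms, with dipentylamino in place of 2-(dibutylamino)ethyl on a saturated chain carbon, three bonds along the chain from an oxygen on an aromatic ring, gives a 1.5-fold lower number from compound 2 to compound 3 (0.18 log units; within the scatter), so this rearrangement does not separate the two compounds. Dipentylamino in place of propyl at that same place gives a 3.8-fold lower number from compound 1 to compound 3 (0.58 log units; beyond the scatter), which places a second amine-bearing chain on the same side of compound 1 as compound 2. Nothing available explains why these numbers fall as they do.

Open, going by these compounds, is how a piperidine ring or a smaller dimethylamino group would read at this place in this assay. Also open, on these data alone, is whether a carboxylic acid at the chain end would stay on that same side of compound 1.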